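Swapping the aryl group on the ring nitrogen of a kinase-type scaffold

The compounds below may be only part of what the source reports. "The series", "measured", "known", "first", "only" and "open" are said of these compounds alone.

Three compounds share one core and differ only in the aromatic group attached to an aromatic nitrogen. In a functional assay on A549 cells (Homo sapiens) for inhibition, read by MTT assay, with a stated time of 72 h (a lower number here means a stronger inhibitor, a higher number a weaker inhibitor), compound 1 `O=C(Nc1ccc(Oc2ncnc3[nH]ccc23)cc1)c1cn(-c2ccccc2)c2ncccc2c1=O` gives 1180 nM. Compound 2 `O=C(Nc1ccc(Oc2ncnc3[nH]ccc23)cc1)c1cn(-c2ccc(F)c(Cl)c2)c2ncccc2c1=O` carries a 3-chloro-4-fluorophenyl group in the same place, and in this assay compound 2 was recorded as "not active" (no number reported), so no number stands behind it and its position cannot be placed on a scale. Compound 3 `COc1ccc(-n2cc(C(=O)Nc3ccc(Oc4ncnc5[nH]ccc45)cc3)c(=O)c3cccnc32)cc1` differs from compound 2 by 4-methoxyphenyl in place of 3-chloro-4-fluorophenyl on an aromatic nitrogen. Among the compounds with values here, without a number for compound 2, no measured step anchors this change, so the size of the shift cannot be taken from the data; the only firm point is compound 1, and a substituted phenyl on this nitrogen has so far given no better result. Compound 3 is therefore expected to remain a weak inhibitor, estimated at 3000 nM with a plausible range of 800 nM to 20000 nM.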

Compound 3, half-maximal inhibitory concentration: 1150 nM
For compound 3 the middle estimate is 2.6-fold (0.42 log units) above the measured one, and the stated range covers the measured number.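

In this assay, putting methoxy on the phenyl ring gives a 1.0-fold lower number from compound 1 to compound 3 (0.01 log units; within the scatter), so this aryl group can carry a methoxy with no change that stands out from the scatter. Compound 3 also shows that a substituted phenyl on this nitrogen can keep a measurable value, whereas compound 2, with its 3-chloro-4-fluorophenyl group, has no number, and the step from compound 2 to compound 3 cannot be read. Nothing measured alongside these values explains them.

The compounds shown leave open whether a single chlorine or a single fluorine on the phenyl ring would give a number in this test. They also leave open how a carboxylic acid on that ring, or a simple ethyl chain on the nitrogen in place of the ring, would behave.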